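A few compounds are considered here, and "the series" means these few. Any claim that something is new, unique, unknown or untested is made for them only; others in the source may bear on it.

Measured so far:
- compound 1, `CN1CC=C(c2cn(S(=O)(=O)c3cccc(Cl)c3)c3ccccc23)CC1`: 95%
- compound 2, `O=S(=O)(c1ccccc1F)n1cc(C2=CCNCC2)c2ccccc21`: 100%

Both measured compounds share a core and differ in the group on the sulfonyl sulfur. In a functional assay on HeLa cells for inhibition of 5-hydroxytryptamine receptor 6 (Homo sapiens), read by cAMP accumulation (a lower number here means a smaller maximal response, a higher number a larger maximal response), compound 1 reaches 95% and compound 2 reaches 100%. Of the two numbers, that of compound 2 is the higher, but compound 1 lies within the usual scatter of it, so the two are not told apart; both sit at a full maximal response.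

Compound 3, `O=S(=O)(c1nccc2sncc12)n1cc(C2=CCNCC2)c2ccccc21`, has not yet been measured in this assay. It differs from compound 2 as follows: a group of 9 heavy atoms (6 carbon, 2 nitrogen, 1 sulfur; one five-membered aromatic ring with 2 hetero atoms, one six-membered aromatic ring with 1 hetero atom) in place of a group of 7 heavy atoms (6 carbon, 1 fluorine; one six-membered aromatic ring of carbon only), on a sulfonyl sulfur. Among the compounds with values here, no step between measured compounds of this kind is available, so nothing in the data says how such a change moves the maximal response. Since compound 1 and compound 2 both give a full response despite different groups at this position, no step beyond the scatter is expected for compound 3. Compound 3 is estimated to reach 95% in this assay, with a range from 80% to 105%. The step this estimate implies, a number 5 percentage points lower from compound 2 to compound 3 (within the scatter), is expected to lie within the scatter.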

Compound 3, largest response reached (reported as Imax), in percent of the reference or control that the assay uses: 65%
Compound 3: the middle estimate sits 30 percentage points above what was measured; the measured number lies below the stated range.
By their numbers in this assay, from the lowest: compound 3; then compounds 1 and 2 (each within the scatter of the next).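

In this assay, within the data shown here, the group on the sulfonyl sulfur proves able to move the maximal response: with the shared core unchanged, replacing 2-fluorophenyl with the group holding a five-membered and a six-membered aromatic ring gives a number 35 percentage points lower from compound 2 to compound 3 (beyond the scatter) in the one comparison here that differs in a single place. A full response is therefore not guaranteed by the shared core alone, since compound 3 reaches 65% in this series of notes on one change at one position. No available measurement accounts for the step, so its cause stays unassigned.

The entering group differs from 2-fluorophenyl at once in ring count, in hetero atoms and in hydrogen-bond acceptors, from 0 to 3, so these compounds do not show which of these differences goes with the lower response. Also open, going by these compounds, is where simpler groups on the sulfonyl sulfur would fall, such as unsubstituted phenyl, a pyridine ring with a single ring nitrogen, or a thiophene ring, and whether each would stay with compound 2 or move towards compound 3.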